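The source may report more compounds than this note shows. Statements on the series, on what has been measured and on what is new or still open speak of the compounds shown alone.

Measured compounds:
compound 1, `Cc1ccc(-n2nc(C)c3c2NC(=O)[C@H](C)S[C@@H]3c2ccc(Oc3ccccc3)cc2)cc1`, 3400 nM
compound 2, `Cc1ccccc1-n1nc(C)c2c1NC(=O)[C@H](C)S[C@@H]2c1ccc(Oc2cccc(C(=O)O)c2)cc1`, "not active" (no number reported)
compound 3, `Cc1nn(-c2ccccc2Br)c2c1C(c1ccc(Oc3ccccc3)cc1)SC(C)C(=O)N2`, 1800 nM

Three compounds sharing one core have been examined in an assay on isolated protein for agonist activity at Bile acid receptor (Homo sapiens), read by AlphaScreen, with a stated time of 30 min; a lower number here means that less compound is needed, a higher number that more compound is needed for the effect. Compound 1 gives 3400 nM in this assay. Compound 3 gives 1800 nM, and the two numbers lie within the usual scatter of repeated measurements of each other, so no order between compound 1 and compound 3 can be read from them. Compound 2 gave no number at all in this assay and was reported as "not active" (no number reported).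

The step considered here leads from compound 1 to compound 4, `Cc1ccccc1-n1nc(C)c2c1NC(=O)[C@H](C)S[C@@H]2c1ccc(Oc2ccccc2)cc1`, which has not yet been measured in this assay. The two compounds contain the same atoms joined differently: 2-methylphenyl in place of 4-methylphenyl on an aromatic nitrogen. Among the measured compounds shown here, nothing among the measured compounds isolates this particular change, so no measured step can be quoted for it. Given that compound 1 and compound 3 differ at the same ring position and still give numbers within the scatter of one another, the step for compound 4 is expected to stay within the scatter, a 1.3-fold lower number from compound 1 to compound 4 (0.10 log units; within the scatter), with no clear direction. The estimate for compound 4 in this assay is 2700 nM, with a range from 900 nM to 8000 nM.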

Compound 4, half-maximal effective concentration: 1300 nM
Compound 4: middle estimate off by 2.1-fold (0.32 log units), on the high side; the range from low to high includes it.
By their numbers in this assay, from the lowest: compounds 4, 3 and 1 (each within the scatter of the next, the first and the last beyond it).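

In this assay, the shift of the methyl group on the phenyl ring attached to the aromatic nitrogen gives a 2.6-fold lower number from compound 1 to compound 4 (0.42 log units; beyond the scatter) and is a modest change, the first single change among these compounds whose size can be read. The 4-methylphenyl and 2-methylphenyl groups have the same heavy atoms and the same counts of hydrogen-bond donors and acceptors, so this pair shows that the number at this position can change with the placement of the methyl group alone, even though the atoms stay the same. The size of the step is the only thing this pair establishes, and no measurement shown here offers an explanation for it.

A single pair cannot show whether the 2-methylphenyl group is better than an unsubstituted phenyl, or how it would compare with a longer chain such as 2-ethylphenyl or with an amine on the same ring. As far as these compounds go, it also remains open whether the same shift of the methyl group would give a step of similar size with other groups elsewhere on the shared core.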